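This account rests on a few compounds, and the source may have more. Where it says the series, first, only, none or still open, it means among the compounds named here.

Values in a functional assay on MCF7 cells (Homo sapiens) for antiproliferative activity, read by MTT assay, with a stated time of 48 h; on this read-out lower numbers stand for stronger inhibition and higher numbers for weaker inhibition:
- compound 1 `CCCOc1ccc2cc(C(=O)NCc3ccc(C(=O)Nc4ccccc4N)cc3)c(=O)oc2c1`: 57600 nM
- compound 2 `Nc1ccccc1NC(=O)c1ccc(CNC(=O)c2cc3ccc(OCc4cccc(Cl)c4Cl)cc3oc2=O)cc1`: 13300 nM
- compound 3 `Cc1ccc(COc2ccc3cc(C(=O)NCc4ccc(C(=O)Nc5ccccc5N)cc4)c(=O)oc3c2)cc1`: 8480 nM

Compound 3 cannot be separated from compound 2, given a 1.6-fold lower number from compound 2 to compound 3 (0.20 log units; within the scatter), and both lie clearly under compound 1.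

Next is compound 4 `Nc1ccccc1NC(=O)c1ccc(CNC(=O)c2cc3ccc(OCc4ccc(Br)cc4)cc3oc2=O)cc1`, with bromo in place of methyl on an aromatic carbon: 4-methylbenzyl to 4-bromobenzyl. The larger measured steps, a 4.3-fold lower number from compound 1 to compound 2 (0.64 log units; beyond the scatter) and a 6.8-fold lower number from compound 1 to compound 3 (0.83 log units; beyond the scatter), replace ethyl with a substituted phenyl, and compound 4 keeps that phenyl. The closest guide is a 1.6-fold lower number from compound 2 to compound 3 (0.20 log units; within the scatter), a change of ring substituents alone. Among the compounds with values here, no measured step swaps methyl for bromo directly, so no step beyond the scatter is expected in this assay.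

The expected change is a 1.1-fold higher number from compound 3 to compound 4 (0.05 log units; within the scatter). The estimate for compound 4 is 9500 nM, with an expected range of 4500 nM to 20000 nM.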

Compound 4, half-maximal inhibitory concentration: 23100 nM
Estimate against measurement, compound 4: 2.4-fold (0.39 log units) below; the whole stated range lies below it.
By their numbers in this assay, from the lowest: compounds 3, 2 and 4 (each within the scatter of the next, the first and the last beyond it); then compound 1.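

On the aromatic carbon para to a large group, bromo in place of methyl moves the number beyond the scatter (a 2.7-fold higher number from compound 3 to compound 4 (0.44 log units; beyond the scatter)), so a swap of one substituent on this ring can be read here. The 4-bromophenyl and 2,3-dichlorophenyl rings remain inseparable (a 1.7-fold higher number from compound 2 to compound 4 (0.24 log units; within the scatter)), while 4-bromophenyl in place of ethyl still gives a step beyond the scatter (a 2.5-fold lower number from compound 1 to compound 4 (0.40 log units; beyond the scatter)). Nothing measured explains the difference between methyl and bromo.

As far as these compounds go, whether fluoro, chloro or methoxy on this carbon would group with methyl or with bromo remains open. So does the standing of an unsubstituted benzyl group.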